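Aryl triazole variation on the shared core: bromo to hydroxy

A few compounds are considered here, and "the series" means these few. Any claim that something is new, unique, unknown or untested is made for them only; others in the source may bear on it.

Compound 1 `O=C1O[C@H]([C@@H](O)Cn2cc(-c3ccc(Br)cc3)nn2)C(OCc2ccccc2)=C1OCc1ccccc1` carries a 4-bromophenyl on the triazole. In a functional assay on SW-620 cells (Homo sapiens) for antiproliferative activity, read by MTT assay, with a stated time of 72 h (a higher number here means a weaker inhibitor, a lower number a stronger inhibitor), compound 1 gives 3760 nM, the lower of the two numbers recorded so far. Compound 2 `O=C1O[C@H]([C@@H](O)Cn2cc(-c3cc(C(F)(F)F)cc(C(F)(F)F)c3)nn2)C(OCc2ccccc2)=C1OCc1ccccc1` gives 49200 nM, a gap that lies beyond the scatter. Compound 3 `O=C1O[C@H]([C@@H](O)Cn2cc(-c3cccc(O)c3)nn2)C(OCc2ccccc2)=C1OCc1ccccc1` differs from compound 1 by 3-hydroxyphenyl in place of 4-bromophenyl on an aromatic carbon. Among the measured compounds shown here, no measured pair shows this exchange, so the step from compound 1 to compound 3 is expected to be small, leaning toward a weaker inhibitor, about a 2.1-fold higher number from compound 1 to compound 3 (0.33 log units; beyond the scatter). Compound 3 is therefore estimated at 8000 nM, within 2500 nM to 30000 nM.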

Compound 3, half-maximal inhibitory concentration: > 100000 nM
Compound 3 ended at the assay's limit; the forecaster's own chance of this, stated with the estimate: 10%; middle value at least 12-fold (1.09 log units) away from the limit.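

On the aryl group at the triazole carbon, activity proves sensitive to the substituent: 3-hydroxyphenyl in place of 4-bromophenyl gives an at least 26-fold higher number from compound 1 to compound 3 (1.42 log units; beyond the scatter). The value of compound 3, > 100000 nM, is a limit of the assay and not a number: the limit of > 100000 nM in this assay, at which 1 of the 3 values shown sits. This single exchange alters both the substituent and its place on the phenyl ring, so the two effects cannot be separated.

The compounds shown leave open which of the two drives the loss. They also leave open how an amine at either place on the phenyl ring would read.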